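The source may report more compounds than this note shows. Statements on the series, on what has been measured and on what is new or still open speak of the compounds shown alone.

Compound 1 `COc1cc2c(cc1OC)C(CC(=O)Nc1ccccc1)CC2` serves as the starting point of this comparison. In a functional assay on the whole organism (strain Wistar) for inhibition, with Rattus norvegicus as the target, read by paw edema, with a stated time of 6 h, at a dose of 100 mg/kg (on this read-out lower numbers stand for less inhibition and higher numbers for more inhibition at the one dose given (going by the name of the read-out)), compound 1 gives 38.9%, the higher of the two numbers recorded so far. Its nearest neighbour, compound 2 `COc1cc2c(cc1OC)C(CC(=O)Nc1ccccc1C)CC2`, carries a methyl in place of hydrogen on an aromatic carbon; in this assay compound 2 gives 25.9%. That single change gave a number 13 percentage points lower from compound 1 to compound 2 (beyond the scatter), a drop that lies beyond the scatter.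

Compound 3 `COc1cc2c(cc1OC)C(CC(=O)Nc1ccc([N+](=O)[O-])cc1)CC2` has not yet been measured. It differs from compound 1 as follows: nitro in place of hydrogen on an aromatic carbon. The group enters on an aromatic carbon of a six-membered aromatic ring of carbon only. Going by the values given here, the only measured step that bears on this change is the one from compound 1 to compound 2, a modest lowering, yet a nitro is not a methyl, and no measured compound carries a nitro. The account therefore expects a step of a number 5.9 percentage points lower from compound 1 to compound 3 (within the scatter), close to the scatter, and estimates that compound 3 will give 33% in this assay, within a range from 18% to 48%.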

Compound 3, a percentage reported as inhibition, in the whole organism at one dose (the size of the read-out at that dose, not a potency): 37%
Beside the measured number, compound 3's estimate is 4 percentage points below it, within the range that was stated.
By their numbers in this assay, from the lowest: compound 2; then compounds 3 and 1 (each within the scatter of the next).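

In this assay, placing a nitro on the aromatic carbon para to a large group gives a number 1.9 percentage points lower from compound 1 to compound 3 (within the scatter), so at this position the change leaves the number where the parent compound has it. Going by these compounds alone, the only earlier step, a number 13 percentage points lower from compound 1 to compound 2 (beyond the scatter), was beyond the scatter and, taken alone, might have suggested that any added group on this ring lowers the number; compound 3 shows that this does not hold for every group on the ring, at least for a nitro in this place at the one dose and time given. Nothing measured here accounts for the difference between the methyl step and the nitro step, and no data explain why the nitro leaves the number within the scatter of compound 1.

What the compounds shown leave open is whether other groups in the same place, such as an amine, a carboxylic acid or a single chlorine atom, would also stay within the scatter of compound 1 or would fall away from it as the methyl compound did. They also leave open whether a nitro would give the same result on another carbon of this ring, and whether the result would hold at other doses.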